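Hydrogen for fluoro on two related amide series

The compounds below may be only part of what the source reports. "The series", "measured", "known", "first", "only" and "open" are said of these compounds alone.

Compound 1, `Cc1nc(-c2ccccc2)c(C(=O)N2CCN(c3cccc(Cl)c3)CC2)o1`, gives 39.2 nM in a functional assay on HL-60 cells (Homo sapiens) for inhibition, read by MTT assay, with a stated time of 72 h; on this read-out higher numbers stand for weaker inhibition and lower numbers for stronger inhibition.
Compound 2, `COc1cc(OC)cc(N2CCN(C(=O)c3onc(C)c3-c3ccccc3F)CC2)c1`, gives 165 nM in this assay.
Compound 3, `Cc1nc(-c2cccc(F)c2)c(C(=O)N2CCN(c3cccc(Cl)c3)CC2)o1`, gives 33.7 nM in this assay.

Compound 3 and compound 1 differ only by hydrogen in place of fluoro on an aromatic carbon, and the step is a 1.2-fold higher number from compound 3 to compound 1 (0.07 log units; within the scatter). Compound 2 stands apart from both; the difference between its core and the core of compound 3 is not broken down here, and its number is higher than that of either.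

Compound 4, `COc1cc(OC)cc(N2CCN(C(=O)c3onc(C)c3-c3ccccc3)CC2)c1`, has not yet been measured. It differs from compound 2 by hydrogen in place of fluoro on an aromatic carbon. The place is not identical to the earlier one, meta to a large group there against ortho to a large group here, so this is the same kind of change rather than the same change. Because the earlier step was a 1.2-fold higher number from compound 3 to compound 1 (0.07 log units; within the scatter), the step from compound 2 to compound 4 in this assay is expected to be small, a 1.1-fold higher number from compound 2 to compound 4 (0.04 log units; within the scatter). Compound 4 is therefore estimated at 180 nM, expected between 80 nM and 400 nM.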

Compound 4, half-maximal inhibitory concentration: 152 nM
Beside the measured number, compound 4's estimate is 1.2-fold (0.07 log units) above it; measured number inside the range.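

In this assay, going from 2-fluorophenyl to phenyl gives a 1.1-fold lower number from compound 2 to compound 4 (0.04 log units; within the scatter). Set beside the earlier step, hydrogen for fluoro reads the same on the two cores: the same change on two cores in this assay, a 1.2-fold higher number (0.07 log units; within the scatter) from compound 3 to compound 1 and a 1.1-fold lower number (0.04 log units; within the scatter) from compound 2 to compound 4, 1.3-fold (0.10 log units) apart, within the scatter of two such steps. Within the data shown here, this shows that the change produced no step beyond the scatter at either of these two places, but it rests on only two pairs, whose places on the ring differ, so it does not show that the result would carry to other places or other cores.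

The compounds shown leave open whether the two cores would also agree with a nitrile, a methoxy group or an amine in place of the fluoro. They also leave open whether any such group would produce a step beyond the scatter.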